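Trading a Cyclopropyl for a Fluoro in Hepatocytes

This account rests on a few compounds, and the source may have more. Where it says the series, first, only, none or still open, it means among the compounds named here.

Measured compounds:
compound 1, `COc1nc(C2=NOCC(c3ccc(Cl)c(F)c3)N2)ccc1-n1cnc(C)c1`, 32 mL/min/kg
compound 2, `COc1nc(C2=NOCC(c3ccc(Cl)c(C4CC4)c3)N2)ccc1-n1cnc(C)c1`, 274 mL/min/kg
compound 3, `COc1nc(C2=NOCC(c3ccc(C4CC4)c(Cl)c3)N2)ccc1-n1cnc(C)c1`, 1150 mL/min/kg

These three share one core and differ only in the substituted phenyl ring. In an ADME assay on cells (Hepatocyte, Homo sapiens) for pharmacokinetics (on this read-out higher numbers stand for fast clearance and lower numbers for slow clearance), compound 3 gives the highest number of the three. Its ring is swapped relative to compound 2, 3-chloro-4-cyclopropylphenyl in place of 4-chloro-3-cyclopropylphenyl on a saturated ring carbon, and that step is a 4.2-fold higher number from compound 2 to compound 3 (0.62 log units; beyond the scatter). Against compound 1 the gap is a 36-fold higher number from compound 1 to compound 3 (1.56 log units; beyond the scatter).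

The change from compound 2 to compound 1, fluoro in place of cyclopropyl on an aromatic carbon, gave an 8.6-fold lower number from compound 2 to compound 1 (0.93 log units; beyond the scatter). Compound 4, `COc1nc(C2=NOCC(c3ccc(F)c(Cl)c3)N2)ccc1-n1cnc(C)c1`, carries the same kind of change made on compound 3 (fluoro in place of cyclopropyl on an aromatic carbon); around the place, the group sits para to a large group rather than meta to it.

Compound 4 is expected to follow the earlier step, with an estimated 8.2-fold lower number from compound 3 to compound 4 (0.91 log units; beyond the scatter) resting on an 8.6-fold lower number from compound 2 to compound 1 (0.93 log units; beyond the scatter). Compound 4 is therefore estimated at 140 mL/min/kg, likely between 45 mL/min/kg and 450 mL/min/kg.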

Compound 4, clearance: 13 mL/min/kg
For compound 4 the middle estimate is 11-fold (1.03 log units) above the measured one, outside the stated range (below it).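

Replacing cyclopropyl with fluoro lowered the number in this assay on both cores, but the size of the step did not carry over: the same change on two cores in this assay, an 8.6-fold lower number (0.93 log units; beyond the scatter) from compound 2 to compound 1 and an 88-fold lower number (1.95 log units; beyond the scatter) from compound 3 to compound 4, 10-fold (1.01 log units) apart, beyond the scatter of two such steps. The direction held in these two pairs, yet the step of an 88-fold lower number from compound 3 to compound 4 (1.95 log units; beyond the scatter) shows that a size measured on one core is a poor guide to the size on another. Two pairs cannot show why the sizes differ or how other cores would behave, and the whole-ring swaps, a 21-fold lower number from compound 2 to compound 4 (1.32 log units; beyond the scatter) and a 2.5-fold lower number from compound 1 to compound 4 (0.39 log units; beyond the scatter), change more than one group at once and so do not settle it.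

From the compounds shown here alone, whether a nitrile or a methoxy group in that place would follow the smaller step or the larger one stays open. So does what a bromo group in place of the chloro would do.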